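Shrinking the Amide Ring: Piperidine to Azetidine

This account rests on a few compounds, and the source may have more. Where it says the series, first, only, none or still open, it means among the compounds named here.

Compound 1, `C=C(C)C(=O)NCCOc1ccc(Oc2c(-c3ccc(F)cc3)sc3cc(O)ccc23)cc1`: > 25000 nM, a limit of the assay.
Compound 2, `O=C(/C=C/CNCCOc1ccc(Oc2c(-c3ccc(F)cc3)sc3cc(O)ccc23)cc1)N1CCCCC1`: 16400 nM.
Compound 3, `CN(C)C(=O)/C=C/CNCCOc1ccc(Oc2c(-c3ccc(F)cc3)sc3cc(O)ccc23)cc1`: 13800 nM.

All three share one core and differ only in the group carried on an amine nitrogen. In a functional assay on MCF7 cells (Homo sapiens) for antiproliferative activity, read by CCK-8 assay, with a stated time of 48 h (on this read-out higher numbers stand for weaker inhibition and lower numbers for stronger inhibition), compound 1 gives only a limit, (the limit of > 25000 nM in this assay, at which 1 of the 3 values shown sits). Among the two real numbers, compound 2 gives the higher one, and its nearest neighbour is compound 3, with a 1.2-fold lower number from compound 2 to compound 3 (0.07 log units; within the scatter). From the limit, the steps are an at least 1.5-fold lower number from compound 1 to compound 2 (0.18 log units; that floor lies within the scatter) and an at least 1.8-fold lower number from compound 1 to compound 3 (0.25 log units; that floor lies within the scatter).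

Compound 4, `O=C(/C=C/CNCCOc1ccc(Oc2c(-c3ccc(F)cc3)sc3cc(O)ccc23)cc1)N1CCC1`, is not yet measured. Its change from compound 2 is azetidin-1-yl in place of piperidin-1-yl on a carbonyl carbon, a four-membered ring entering where a six-membered one leaves, both on the carbonyl carbon of the same amide. Among the measured compounds shown here, the only measured step that bears on this place is the swap of amide substituent from compound 2 to compound 3, a 1.2-fold lower number from compound 2 to compound 3 (0.07 log units; within the scatter), which lay within the scatter. The expected step is therefore a 1.1-fold lower number from compound 2 to compound 4 (0.04 log units; within the scatter), no change beyond the scatter. Compound 4 is estimated at 15000 nM, with a range from 7000 nM to 30000 nM.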

Compound 4, half-maximal inhibitory concentration: 7340 nM
Estimate against measurement, compound 4: 2.0-fold (0.31 log units) above; the range from low to high includes it.
By their numbers in this assay, from the lowest: compounds 4, 3 and 2 (each within the scatter of the next, the first and the last beyond it). At a limit, above all of these: compound 1.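

Azetidin-1-yl in place of piperidin-1-yl gives a 2.2-fold lower number from compound 2 to compound 4 (0.35 log units; beyond the scatter) in this assay and is the first change on this carbonyl carbon to pass the scatter, so the amide substituent can shift the read-out here. The comparison with the open-chain dimethylamino amide is less firm: a 1.9-fold lower number from compound 3 to compound 4 (0.27 log units; within the scatter) means that compound 3 and compound 4 cannot be put in order. Starting from (1-methylethenyl)carbonyl on the amine nitrogen, the reading of an at least 3.4-fold lower number from compound 1 to compound 4 (0.53 log units; beyond the scatter) is the first from that side to clear the scatter, though its starting value is a limit and not a number: the limit of > 25000 nM in this assay, at which 1 of the 4 values shown sits.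

From the compounds shown here alone, two ring sizes cannot show a trend, so it remains open whether a five-membered pyrrolidin-1-yl ring on the same carbonyl carbon would fall between compound 2 and compound 4. Going by these compounds, it is also open how a morpholin-4-yl ring, which carries an added oxygen, would read there.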